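The source may report more compounds than this note shows. Statements on the series, on what has been measured and on what is new or still open speak of the compounds shown alone.

In a functional assay on MOLT-4 cells (Homo sapiens) for antiproliferative activity, read by MTT assay, with a stated time of 3 days (on this read-out lower numbers stand for stronger inhibition and higher numbers for weaker inhibition), compound 1 (`CCCCCCC#Cc1cn(C/C=C/CN2C(=O)c3ccccc3C2=O)c(=O)[nH]c1=O`) gives 35000 nM and compound 2 (`CCCCCc1ccc(C#Cc2cn(C/C=C/CN3C(=O)c4ccccc4C3=O)c(=O)[nH]c2=O)cc1`) gives 17000 nM, while compound 3 (`CCCCc1ccc(C#Cc2cn(C/C=C/CN3C(=O)c4ccccc4C3=O)c(=O)[nH]c2=O)cc1`) gives 29000 nM on the same read-out. Compound 3 stands within the scatter of both others, as a 1.2-fold lower number from compound 1 to compound 3 (0.08 log units; within the scatter) and a 1.7-fold higher number from compound 2 to compound 3 (0.23 log units; within the scatter) show. Compound 4 (`O=C1c2ccccc2C(=O)N1C/C=C/Cn1cc(C#CCCc2ccccc2)c(=O)[nH]c1=O`) brings a new change, phenethyl in place of 4-butylphenyl on a triple-bonded carbon in all: phenethyl in place of 4-butylphenyl on a triple-bonded carbon. Going by the values given here, with a 2.1-fold lower number from compound 1 to compound 2 (0.31 log units; beyond the scatter) and a 1.2-fold lower number from compound 1 to compound 3 (0.08 log units; within the scatter) as the only other steps on that same carbon, both small, no step beyond the scatter is expected in this assay here. The estimated size is a 1.0-fold lower number from compound 3 to compound 4 (0.02 log units; within the scatter) on this reasoning. For compound 4 the expected value is 28000 nM with an estimated range from 12000 nM to 60000 nM as the likely span.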

Compound 4, half-maximal inhibitory concentration: 39000 nM
For compound 4 the middle estimate is 1.4-fold (0.14 log units) below the measured one; the measured number falls inside the stated range.
By their numbers in this assay, from the lowest: compounds 2, 3, 1 and 4 (each within the scatter of the next, the first and the last beyond it).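

In this assay, phenethyl on this triple-bonded carbon gives no clear change from 4-butylphenyl (a 1.3-fold higher number from compound 3 to compound 4 (0.13 log units; within the scatter)) or from the hexyl chain, counted here as phenyl in place of butyl (a 1.1-fold higher number from compound 1 to compound 4 (0.05 log units; within the scatter)). Only the comparison with 4-pentylphenyl goes beyond the scatter, and modestly (a 2.3-fold higher number from compound 2 to compound 4 (0.36 log units; beyond the scatter)). Nothing measured here explains this gap. Still open, going by these compounds, is whether an amine or a carboxylic acid on a chain at this triple-bonded carbon would shift the number further than any of these groups.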